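Swapping Pyrazolyl for Anilino in a Phosphodiesterase Series

The source may hold more compounds than are shown below. What is called first, only, known or untested is meant among the compounds shown, and "the series" means these compounds.

Three compounds share a core and were tested in an in vitro assay on Sf21 cells for inhibition of high affinity 3',5'-cyclic-AMP phosphodiesterase 7A (Homo sapiens); on this read-out higher numbers stand for weaker inhibition and lower numbers for stronger inhibition:

Compound 1 `CNc1nc(NC2(C#N)CCCCC2)nc(OC)n1` gives 521 nM.
Compound 2 `CNc1nc(NC2(C#N)CCCCC2)nc(N(C)C)n1` gives > 5000 nM, which is a limit of the assay.
Compound 3 `CNc1nc(NC2(C#N)CCCCC2)nc(-n2cccn2)n1` gives > 5000 nM, which is a limit of the assay.

Compound 3 thus stands at the weak end of what was seen; its value is a limit only, as it is for one other compound here, (the limit of > 5000 nM in this assay, at which 2 of the 3 values shown sit). The step to compound 4 `CNc1nc(Nc2ccccc2)nc(NC2(C#N)CCCCC2)n1` replaces one group on the shared core: anilino in place of 1H-pyrazol-1-yl on an aromatic carbon.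

Only the change into compound 3 is readable: an at least 9.5-fold higher number from compound 1 to compound 3 (0.98 log units; beyond the scatter). The step from the dimethylamino compound is a step that the two limits leave unreadable from compound 2 to compound 3. Anilino is neither methoxy nor pyrazolyl, so the measured steps give no firm direction; the one numeric point, compound 1, shows where a small group at this position lands. For compound 4 a modest gain is expected, an at least 2.0-fold lower number from compound 3 to compound 4 (0.30 log units; that floor lies within the scatter), with a fair chance that again only a limit is reported. The estimate for compound 4 in this assay is 2500 nM, between 500 nM and 10000 nM.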

Compound 4, half-maximal inhibitory concentration: > 5000 nM
Compound 4: no number, only a limit (the forecaster's own chance of this, stated with the estimate: 40%); middle value at least 2.0-fold (0.30 log units) from the limit.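

In this assay compound 4 gives > 5000 nM, which is a limit of the assay and not a number. An aromatic ring of carbon only, joined through a nitrogen that carries a hydrogen-bond donor, therefore does not bring a measurable value back at this position, and going from methoxy to anilino gives an at least 9.5-fold higher number from compound 1 to compound 4 (0.98 log units; beyond the scatter). Methoxy remains the only group here with a measured number, while the steps among compound 2, compound 3 and compound 4 cannot be read, and their values gather at one point: the limit of > 5000 nM in this assay, at which 3 of the 4 values shown sit.

As far as these compounds go, whether ethoxy or methylthio at this position would also give a measured number stays open. So does the question of how far compound 2, compound 3 and compound 4 differ from one another.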